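Pyridinyl alkynyl phenylpropanoic acids: efficacy notes

This account rests on a few compounds, and the source may have more. Where it says the series, first, only, none or still open, it means among the compounds named here.

Measured so far:
compound 1 `Cc1c(C#Cc2ccc(CCC(=O)O)cc2)ccnc1Cl` gives 101%
compound 2 `Cc1c(C#Cc2ccc(CCC(=O)O)cc2)cc(Cl)nc1Cl` gives 91%
compound 3 `O=C(O)CCc1ccc(C#Cc2ccc(Cl)nc2)cc1` gives 98%

All three values come from an in vitro functional assay on 1321-N1 cells for agonist activity at Free fatty acid receptor 1 (Homo sapiens), read by fluorescence, spectrophotometry and calcium flux; a higher number here means a larger maximal response, a lower number a smaller maximal response. Compound 2 and compound 1 differ by hydrogen in place of chloro on an aromatic carbon and that step is a number 10 percentage points higher from compound 2 to compound 1 (within the scatter). How the core of compound 3 differs from the core of compound 2 is not broken down here; in this assay compound 3 and compound 2 give values within the scatter of each other.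

Compound 4 `O=C(O)CCc1ccc(C#Cc2cccnc2)cc1` is not yet measured. It differs from compound 3 by hydrogen in place of chloro on an aromatic carbon. This is the same kind of change as from compound 2 to compound 1, but the place differs: in compound 3 the carbon is para to a large group, whereas in compound 2 it is meta to a chloro group, meta to a large group and para to a methyl group.

Because the earlier step of a number 10 percentage points higher from compound 2 to compound 1 (within the scatter) stayed within the scatter, the step of a number 2 percentage points higher from compound 3 to compound 4 (within the scatter) is expected to be small as well. For compound 4 the expected value in this assay is 100%, between 88% and 110%.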

Compound 4, largest response reached (reported as efficacy), in percent of the reference or control that the assay uses: 96%
The estimate for compound 4 lay 4 percentage points above the measured number, and the stated range covers the measured number.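

In this assay, hydrogen in place of chloro on an aromatic carbon gives a number 2 percentage points lower from compound 3 to compound 4 (within the scatter). Set beside the earlier step, the same change shows no difference between the two cores: the same change on two cores in this assay, a number 10 percentage points higher (within the scatter) from compound 2 to compound 1 and a number 2 percentage points lower (within the scatter) from compound 3 to compound 4, 12 percentage points apart, within the scatter of two such steps

This supports carrying the change between these two cores for the maximal response only, and it does not show that the change has no effect on any other core or at any other place on the ring.

Going by these compounds, whether an amine or a nitrile in place of the chloro would leave the maximal response within the same scatter remains open. The same question stands for a longer chain bearing the carboxylic acid.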